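This account rests on a few compounds, and the source may have more. Where it says the series, first, only, none or still open, it means among the compounds named here.

Series notes. The shared core carries, on an aromatic carbon, one variable group, across compound 1 (`Cc1c(Cc2ccc(C(C)(C)C)cc2)c(=O)oc2cc(OCC(O)CN3CCC(C(N)=O)CC3)ccc12`), compound 2 (`COC(=O)c1ccc(Cc2c(C)c3ccc(OCC(O)CN4CCC(C(N)=O)CC4)cc3oc2=O)cc1`) and compound 3 (`Cc1noc(C)c1-c1ccc(Cc2c(C)c3ccc(OCC(O)CN4CCC(C(N)=O)CC4)cc3oc2=O)cc1`). In an ADME assay on A549 cells (Homo sapiens) for cytotoxicity, read by CellTiter-Glo (a lower number here means that less compound is tolerated, a higher number that more compound is tolerated), compound 1 gives 14700 nM and compound 3 gives 36900 nM. Compound 2 reaches only the limit of > 100000 nM; this is the limit of > 100000 nM in this assay, at which 1 of the 3 values shown sits. Of the two numbers compound 3 stands highest, with a 2.5-fold higher number from compound 1 to compound 3 (0.40 log units; beyond the scatter) and an at least 2.7-fold lower number from compound 2 to compound 3 (0.43 log units; beyond the scatter). Compound 4 (`Cc1c(Cc2ccc(-c3ccccc3C#N)cc2)c(=O)oc2cc(OCC(O)CN3CCC(C(N)=O)CC3)ccc12`) is not yet measured; it differs from compound 3 by 2-cyanophenyl in place of 3,5-dimethyl-1,2-oxazol-4-yl on an aromatic carbon. Both measured steps at this position moved the number beyond the scatter, in opposite directions, so no direction is firmly indicated; a step within the scatter is expected, a 1.2-fold lower number from compound 3 to compound 4 (0.09 log units; within the scatter). For compound 4 the estimate in this assay is 30000 nM, with a range from 12000 nM to 80000 nM.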

Compound 4, half-maximal cytotoxic concentration: 33200 nM
Estimate against measurement, compound 4: 1.1-fold (0.04 log units) below, and the stated range covers the measured number.
By their numbers in this assay, from the lowest: compound 1; then compounds 4 and 3 (each within the scatter of the next). At a limit, above all of these: compound 2.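

Exchanging one aromatic ring for another at this position, 2-cyanophenyl for 3,5-dimethyl-1,2-oxazol-4-yl, leaves this assay unmoved, with a 1.1-fold lower number from compound 3 to compound 4 (0.05 log units; within the scatter). The 2-cyanophenyl group also gives a 2.3-fold higher number from compound 1 to compound 4 (0.35 log units; beyond the scatter) in place of tert-butyl, and an at least 3.0-fold lower number from compound 2 to compound 4 (0.47 log units; beyond the scatter) in place of methoxycarbonyl. Compound 2 stands at a limit, not a number: the limit of > 100000 nM in this assay, at which 1 of the 4 values shown sits.

Still open, as far as these compounds go, is how an unsubstituted phenyl, a carboxylic acid or an amine would read on this aromatic carbon. Also open, from the compounds shown here alone, is whether the nitrile of 2-cyanophenyl contributes anything to the number.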